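Compound 4: Piperazin-1-yl Replaces Diethylamino in Compound 2

The compounds below may be only part of what the source reports. "The series", "measured", "known", "first", "only" and "open" are said of these compounds alone.

Three compounds share one core, measured in a functional assay on A549 cells (Homo sapiens) for cytotoxicity, read by MTT assay, with a stated time of 48 h; a higher number here means a weaker inhibitor, a lower number a stronger inhibitor. Compound 1 `COc1c(OCCCN2CCN(C)CC2)cc(O)c2c(=O)cc(-c3ccccc3)oc12` gives 9900 nM. Compound 2 `CCN(CC)CCCCOc1cc(O)c2c(=O)cc(-c3ccccc3)oc2c1OC` gives 1000 nM, the lowest of the two numbers available; compound 3 `CNCCOc1c(O)cc(O)c2c(=O)cc(-c3ccccc3)oc12` has no result reported in this assay, with "not determined" (no result reported). Going by the values given here, the single measured step, a 9.9-fold lower number from compound 1 to compound 2 (1.00 log units; beyond the scatter), is beyond the scatter and shows that swapping a ring amine at the chain end for an open diethylamino went with a markedly lower number.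

Compound 4 `COc1c(OCCCCN2CCNCC2)cc(O)c2c(=O)cc(-c3ccccc3)oc12` is the next entry. piperazin-1-yl in place of diethylamino on a saturated chain carbon, four bonds along the chain from an oxygen on an aromatic ring

Among the compounds with values here, the only step that bears on this change runs in the opposite sense: compound 1 carries a piperazine ring at its chain end, and compound 2, with the open amine, was the stronger of the pair by a 9.9-fold lower number from compound 1 to compound 2 (1.00 log units; beyond the scatter). Returning to a piperazine ring, now with a hydrogen-bond donor in place of the methyl, is therefore expected to move the number back upward, though not necessarily all the way, since the chain length of compound 2 is kept. The expected step is a 4.0-fold higher number from compound 2 to compound 4 (0.60 log units; beyond the scatter). Compound 4 is thus estimated at 4000 nM, within a range from 1500 nM to 15000 nM.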

Compound 4, half-maximal inhibitory concentration: 1740 nM
For compound 4 the middle estimate is 2.3-fold (0.36 log units) above the measured one; the range from low to high includes it.
By their numbers in this assay, from the lowest: compounds 2 and 4 (each within the scatter of the next); then compound 1.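

In this assay, the step to compound 4 shows that this position tolerates a ring amine: with piperazin-1-yl in place of diethylamino at the end of the same chain, there is a 1.7-fold higher number from compound 2 to compound 4 (0.24 log units; within the scatter), so compounds 2 and 4 cannot be told apart. The earlier step from compound 1 to compound 2 had left open whether a ring at the chain end went with the higher number, but compound 4 carries a piperazine ring and still stands clear of compound 1, with a 5.7-fold lower number from compound 1 to compound 4 (0.76 log units; beyond the scatter). Among these three measured compounds, a piperazine ring at the chain end therefore does not by itself go with the higher number seen for compound 1.

The step from compound 1 to compound 4 changes both the chain and the methyl on the ring, so these compounds cannot show which of the two goes with the gap. On these data alone, it also remains open whether a morpholine ring, a primary amine or a longer chain at this place would stay level with compounds 2 and 4. No measurement offered here accounts for these numbers.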